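Moving the Chlorine: From Compound 2 to Compound 4

The compounds below may be only part of what the source reports. "The series", "measured", "known", "first", "only" and "open" are said of these compounds alone.

Of the compounds shown here, three built on one shared core have been measured in a functional assay on A-375 cells (Homo sapiens) for antiproliferative activity, read by MTT assay, with a stated time of 48 h; on this read-out lower numbers stand for stronger inhibition of growth and higher numbers for weaker inhibition of growth. Compound 1 `S=C(Nc1ccccc1)N1N=C(c2ccc(Cl)cc2)CC1c1ccc2c(c1)OCCO2` gives 195000 nM. Compound 2 `Cc1ccc(C2=NN(C(=S)Nc3ccccc3)C(c3ccc4c(c3)OCCO4)C2)cc1` gives 6320 nM, and compound 3 `COc1ccccc1C1=NN(C(=S)Nc2ccccc2)C(c2ccc3c(c2)OCCO3)C1` gives 20300 nM. Compound 2 stands lowest of the three numbers: compound 3 is nearest to it, as seen in a 3.2-fold higher number from compound 2 to compound 3 (0.51 log units; beyond the scatter), while compound 1 is furthest, as seen in a 31-fold lower number from compound 1 to compound 2 (1.49 log units; beyond the scatter).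

The unmeasured compound 4 `S=C(Nc1ccccc1)N1N=C(c2cccc(Cl)c2)CC1c1ccc2c(c1)OCCO2` is reached from compound 2 by a single change: 3-chlorophenyl in place of 4-methylphenyl on a carbon with a double bond to nitrogen. The ring that enters carries chlorine where the ring that leaves carried methyl, though the chlorine now sits on a different aromatic carbon than in compound 1.

The step that bears most directly on this is a 31-fold lower number from compound 1 to compound 2 (1.49 log units; beyond the scatter), a large drop when methyl replaced chloro. The steps of a 9.6-fold lower number from compound 1 to compound 3 (0.98 log units; beyond the scatter) and a 3.2-fold higher number from compound 2 to compound 3 (0.51 log units; beyond the scatter) show that other exchanges of the aryl group moved the number by modest amounts. The writer therefore expects a higher number from compound 2 to compound 4, a 7.9-fold higher number from compound 2 to compound 4 (0.90 log units; beyond the scatter), beyond the scatter, but not necessarily the full size of a 31-fold lower number from compound 1 to compound 2 (1.49 log units; beyond the scatter). Compound 4 is estimated at 50000 nM, within a range from 10000 nM to 250000 nM.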

Compound 4, concentration for 50% growth inhibition: > 200000 nM
Compound 4: a limit, no number (the forecaster's own chance of this, stated with the estimate: 10%); middle value at least 4.0-fold (0.60 log units) away from the limit.
By their numbers in this assay, from the lowest: compound 2; then compound 3; then compound 1. At a limit, above all of these: compound 4.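

Compound 4 stands at a limit of the assay and not at a number: the limit of > 200000 nM in this assay, at which 1 of the 4 values shown sits. On the carbon with a double bond to nitrogen, 3-chlorophenyl in place of 4-methylphenyl gives an at least 31-fold higher number from compound 2 to compound 4 (1.50 log units; beyond the scatter), and 3-chlorophenyl in place of 2-methoxyphenyl gives an at least 9.8-fold higher number from compound 3 to compound 4 (0.99 log units; beyond the scatter), so both steps are floors that lie beyond the scatter, while 3-chlorophenyl in place of 4-chlorophenyl gives an at least 1.0-fold higher number from compound 1 to compound 4 (0.01 log units; that floor lies within the scatter) and so the 3-chlorophenyl and 4-chlorophenyl groups cannot be ordered. Before this result, only compound 1 carried a chlorophenyl group here; with compound 4 there are two such compounds, and both lie far on the weak side of compound 2 and compound 3, with no compound among these four going against that.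

The compounds shown leave open how far compound 4 lies past its limit, and whether the gain seen with 4-methylphenyl depends on where the methyl sits, as a 3-methylphenyl group would test. They also leave open whether a phenyl ring carrying fluoro, hydroxyl, an amine or a carboxylic acid at this position would stay near compound 2 or fall with the two chlorophenyl compounds.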